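The source may hold more compounds than are shown below. What is called first, only, known or untested is meant among the compounds shown, and "the series" means these compounds.

Three compounds have been measured in a functional assay on A-375 cells (Homo sapiens) for cytotoxicity, read by MTT assay; on this read-out higher numbers stand for weaker inhibition and lower numbers for stronger inhibition:

compound 1, `O=S(=O)(NCCCNc1nccc(-c2c(-c3cccc(F)c3)nc3sccn23)n1)c1ccc(Br)cc1`, 7040 nM
compound 2, `O=S(=O)(NCCCNc1nccc(-c2c(-c3cccc(F)c3)nc3sccn23)n1)c1ccc(F)cc1`, 14500 nM
compound 3, `O=S(=O)(NCCNc1nccc(-c2c(-c3cccc(F)c3)nc3sccn23)n1)c1ccc(Br)cc1`, 13500 nM

Compound 2 stands at the highest of these three numbers. Its nearest neighbour is compound 3, and those two values lie within the scatter of repeated measurements. Within the data shown here, the gap to compound 1 is wider: there is a 2.1-fold higher number from compound 1 to compound 2 (0.31 log units; beyond the scatter), a modest step, and the only change behind it is fluoro in place of bromo on an aromatic carbon.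

Compound 4, `O=C(NCCCNc1nccc(-c2c(-c3cccc(F)c3)nc3sccn23)n1)c1ccc(Cl)cc1`, has not yet been measured in this assay. It differs from compound 2 in one place: (4-chlorophenyl)carbonyl in place of (4-fluorophenyl)sulfonyl on an amine nitrogen. Of the measured steps only a 2.1-fold higher number from compound 1 to compound 2 (0.31 log units; beyond the scatter) bears on this change, and only in part, since it shows what exchanging one halogen for another on that aryl ring did, with bromo at the lower number. Among the measured compounds shown here, no measured step touches the exchange of sulfonyl for carbonyl, so that part of the change has nothing to rest on.

Taking chloro as sitting between fluoro and bromo, the expected step is a 1.6-fold lower number from compound 2 to compound 4 (0.21 log units; within the scatter), a small movement toward a lower number. Compound 4 is therefore estimated at 9000 nM, expected to fall between 3000 nM and 30000 nM.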

Compound 4, half-maximal inhibitory concentration: 13700 nM
Compound 4: the middle estimate sits 1.5-fold (0.18 log units) below what was measured; measured number inside the range.
By their numbers in this assay, from the lowest: compounds 1, 3, 4 and 2 (each within the scatter of the next, the first and the last beyond it).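

In this assay, the exchange of (4-fluorophenyl)sulfonyl for (4-chlorophenyl)carbonyl on the amine nitrogen gives a 1.1-fold lower number from compound 2 to compound 4 (0.02 log units; within the scatter) and so shows something the halogen step could not: at this position the sulfonyl can give way to a carbonyl with no change in the read-out beyond the scatter. Set against the two bromo compounds, the same structure gives a 1.9-fold higher number from compound 1 to compound 4 (0.29 log units; within the scatter) and a 1.0-fold higher number from compound 3 to compound 4 (0.01 log units; within the scatter), so compound 4 cannot be told apart from any of the other three, even though compound 1 and compound 2 lie beyond the scatter of each other. Nothing measured here offers an explanation for these readings.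

The compounds shown leave open what the carbonyl and the chloro each contribute, since the two enter together, and (4-chlorophenyl)sulfonyl or (4-fluorophenyl)carbonyl on the same amine nitrogen would separate them. They also leave open whether the carbonyl series responds to chain length as the sulfonyl pair does, which a two-carbon chain or a longer chain carrying (4-chlorophenyl)carbonyl would address.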